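Solubility notes: 2-methoxyethyl to 2-hydroxyethyl change

This account rests on a few compounds, and the source may have more. Where it says the series, first, only, none or still open, it means among the compounds named here.

Measured compounds:
Compound 1, `COCCNS(=O)(=O)CCn1cncc1[N+](=O)[O-]`, in a physicochemical assay for solubility, read by HPLC (on this read-out higher numbers stand for higher solubility and lower numbers for lower solubility), gives 24400000 nM.
Compound 2, `COCCNS(=O)(=O)CCn1cnc([N+](=O)[O-])c1`, in this assay gives 16000000 nM.
Compound 3, `O=[N+]([O-])c1cncn1CCS(=O)(=O)NCCO`, in this assay gives 69300000 nM.

Compound 1 and compound 2 are built from the same atoms joined differently; the difference between the two cores is not broken down here. Their two values lie within the usual scatter of each other. Compound 3 differs from compound 1 by hydrogen in place of methyl on an oxygen on a saturated carbon, and that step reads a 2.8-fold higher number from compound 1 to compound 3 (0.45 log units; beyond the scatter).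

Compound 4, `O=[N+]([O-])c1cn(CCS(=O)(=O)NCCO)cn1`, is not yet measured in this assay. It differs from compound 2 by hydrogen in place of methyl on an oxygen on a saturated carbon, the same change at the same place as between compound 1 and compound 3. A step of about the same size is expected, namely a 2.8-fold higher number from compound 2 to compound 4 (0.45 log units; beyond the scatter). That expectation rests on a 2.8-fold higher number from compound 1 to compound 3 (0.45 log units; beyond the scatter). Compound 4 is therefore estimated at 45000000 nM, likely between 25000000 nM and 90000000 nM.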

Compound 4, solubility: > 100000000 nM
Compound 4 ended at the assay's limit; the forecaster's own chance of this, stated with the estimate: 5%; middle value at least 2.2-fold (0.34 log units) from the limit.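

The change of 2-methoxyethyl to 2-hydroxyethyl reads in the same direction on both cores, with a 2.8-fold higher number from compound 1 to compound 3 (0.45 log units; beyond the scatter) and an at least 6.2-fold higher number from compound 2 to compound 4 (0.79 log units; beyond the scatter). In this assay, compound 4 gives > 100000000 nM, which is a limit of the assay and not a number: the limit of > 100000000 nM in this assay, at which 1 of the 4 values shown sits. As far as these compounds go, the direction therefore carries from one core to the other, but the true size of the second step remains unknown, so these data do not show whether it matches the first.

From the compounds shown here alone, whether the same direction holds on any further core remains open. Also open, going by these compounds, is how an amine, a carboxylic acid or a longer chain in place of 2-hydroxyethyl would read on either core.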